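Cyclopropyl amide to pyrrolidine urea on the shared core

The compounds below may be only part of what the source reports. "The series", "measured", "known", "first", "only" and "open" are said of these compounds alone.

compound 1 `O=C(C1CC1)N1CCc2nc(C#Cc3ccccc3)sc2C1`: > 10000 nM
compound 2 `O=C(N1CCC(F)CC1)N1CCc2nc(C#Cc3ccccc3)sc2C1`: 74 nM

In an assay on HEK293 cells for positive allosteric modulation of metabotropic glutamate receptor 5 (Homo sapiens), read by FLIPR, with a stated time of 1 h (a higher number here means that more compound is needed for the effect, a lower number that less compound is needed), compound 1 gives only a limit, > 10000 nM, so its true value is not known (the limit of > 10000 nM in this assay, at which 1 of the 2 values shown sits). Compound 2 gives 74 nM. Among the measured compounds shown here, the single measured step, an at least 130-fold lower number from compound 1 to compound 2 (2.13 log units; beyond the scatter), bears directly on compound 3 `O=C(N1CCCC1)N1CCc2nc(C#Cc3ccccc3)sc2C1`, whose change reads (pyrrolidin-1-yl in place of cyclopropyl on a carbonyl carbon). That step was large, and compound 3 again puts a ring with an amide-type nitrogen in place of cyclopropyl on the carbonyl carbon, so a large drop is expected for compound 3, an at least 66-fold lower number from compound 1 to compound 3 (1.82 log units; beyond the scatter). Compound 3 is estimated at 150 nM, within 40 nM to 600 nM.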

Compound 3, half-maximal effective concentration: 9.8 nM
Compound 3: the middle estimate sits 15-fold (1.18 log units) above what was measured; the whole stated range lies above it.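

In this assay, the shared core gives an at least 1000-fold lower number from compound 1 to compound 3 (3.00 log units; beyond the scatter), so the gain is not confined to 4-fluoropiperidin-1-yl and also appears with pyrrolidin-1-yl on the carbonyl carbon. The choice of ring at this place also matters, with a 7.6-fold lower number from compound 2 to compound 3 (0.88 log units; beyond the scatter). Compound 1 stands at a limit of the assay, so its step gives a bound only: the limit of > 10000 nM in this assay, at which 1 of the 3 values shown sits.

The compounds shown leave open whether the fluorine or the ring size of 4-fluoropiperidin-1-yl accounts for the gap to pyrrolidin-1-yl. They also leave open how an open-chain dimethylamino group or a morpholin-4-yl ring would read on the same carbonyl carbon.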